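The source may report more compounds than this note shows. Statements on the series, on what has been measured and on what is new or still open speak of the compounds shown alone.

Measured compounds in an assay on cells for inhibition of MAP kinase-interacting serine/threonine-protein kinase 1 (Homo sapiens), read by mobility shift assay, with stated times of 10 min and 60 min, in the presence of a further agent that is not named here; on this read-out lower numbers stand for stronger inhibition and higher numbers for weaker inhibition:
compound 1 `CC(=O)c1cncc(-c2ccc(C(N)=O)cc2)c1`, for which compound 1 gives 8000 nM
compound 2 `Cc1cc(-c2cccnc2)ccc1C(N)=O`, for which compound 2 gives 22000 nM

Compound 2 stands at the highest of the two numbers in this assay. For the measured compounds named here, its nearest neighbour is compound 1, whose number is lower by a margin that lies beyond the usual scatter of such measurements; since the two structures differ in more than one place, the pair shows only that compound 2 is the weaker inhibitor of the two, and no single structural cause can be read from it.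

Compound 3 `NC(=O)c1ccc(-c2cccnc2)cc1OC1CCC1` has not yet been measured in this assay. It differs from compound 2 by one change: cyclobutyloxy in place of methyl on an aromatic carbon. Going by the values given here, no measured pair in this set isolates such a change, so no step size can be taken from the data. Given that, the step from compound 2 to compound 3 is expected to be a 1.8-fold lower number from compound 2 to compound 3 (0.26 log units; within the scatter), a change not clearly beyond the scatter, though with wide uncertainty either way. Compound 3 is therefore estimated at 12000 nM in this assay, with a range from 2500 nM to 60000 nM.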

Compound 3, half-maximal inhibitory concentration: 1900 nM
Estimate against measurement, compound 3: 6.3-fold (0.80 log units) above; the measured number lies below the stated range.
By their numbers in this assay, from the lowest: compound 3; then compound 1; then compound 2.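

In this assay, for the compounds shown here, cyclobutyloxy in place of methyl on the aromatic carbon ortho to the carbamoyl group gives a 12-fold lower number from compound 2 to compound 3 (1.06 log units; beyond the scatter), and this is the first step in the set that can be read as a single change. It shows that this position accepts a group of five heavy atoms in place of one, and that inhibition here grows rather than falls with that exchange. The step does not separate the parts of the entering group, since the oxygen, with its hydrogen-bond acceptor, and the four-membered ring of carbon only enter together, and nothing given here speaks to the cause of the gain.

From the compounds shown here alone, whether the gain follows from the oxygen, from the ring or from the count of heavy atoms stays open, and a methoxy group, a cyclobutyl group bound directly to the aromatic carbon or an open butoxy chain at this place would each bear on that question. Also open, going by these compounds, is whether a chain ending in an amine or a carboxylic acid would keep the gain here, and whether the same exchange would carry over to the core of compound 1.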